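A few compounds are considered here, and "the series" means these few. Any claim that something is new, unique, unknown or untested is made for them only; others in the source may bear on it.

Measured compounds in a functional assay on HL-60 cells (Homo sapiens) for cytotoxicity, read by WST assay, with a stated time of 48 h; on this read-out lower numbers stand for stronger inhibition and higher numbers for weaker inhibition:
compound 1, `Cc1ccc(/C=C/C[C@H]2C[C@@H]([C@@H](O)c3ccccc3)CO[C@@H]2c2ccccc2)cc1C`, 9880 nM
compound 2, `O[C@@H](c1ccccc1)[C@H]1CO[C@H](c2ccccc2)[C@@H](C/C=C/c2ccccc2)C1`, 7040 nM
compound 3, `O=[N+]([O-])c1ccc(/C=C/C[C@H]2C[C@@H]([C@@H](O)c3ccccc3)CO[C@@H]2c2ccccc2)cc1`, 4880 nM

Compound 3 gives the lowest of the three numbers in this assay: a 2.0-fold lower number from compound 1 to compound 3 (0.31 log units; beyond the scatter), whereas compound 2 and compound 3 lie within the scatter of each other, a 1.4-fold lower number from compound 2 to compound 3 (0.16 log units; within the scatter). Compound 4, `O=[N+]([O-])c1cccc(/C=C/C[C@H]2C[C@@H]([C@@H](O)c3ccccc3)CO[C@@H]2c2ccccc2)c1`, differs from compound 3 only at the aryl group: 3-nitrophenyl in place of 4-nitrophenyl on a double-bonded chain carbon bound to a double-bonded chain carbon. Going by the values given here, no measured step moves a nitro group from one ring position to another. Among the compounds with values here, the steps that bear on it are a 1.4-fold lower number from compound 2 to compound 3 (0.16 log units; within the scatter) and a 1.4-fold lower number from compound 1 to compound 2 (0.15 log units; within the scatter), both within the scatter, and the modest 2.0-fold lower number from compound 1 to compound 3 (0.31 log units; beyond the scatter). A step of no size beyond the scatter is therefore expected, a 1.0-fold higher number from compound 3 to compound 4 (0.01 log units; within the scatter). Compound 4 is estimated at 5000 nM, with a range of 2500 nM to 10000 nM.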

Compound 4, half-maximal inhibitory concentration: 6350 nM
Compound 4: the middle estimate sits 1.3-fold (0.10 log units) below what was measured; measured number inside the range.
By their numbers in this assay, from the lowest: compounds 3, 4, 2 and 1 (each within the scatter of the next, the first and the last beyond it).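

In this assay, 3-nitrophenyl in place of 4-nitrophenyl on the double-bonded chain carbon gives a 1.3-fold higher number from compound 3 to compound 4 (0.11 log units; within the scatter), so this aryl site shows no separation between the two nitrophenyl groups. Nitro in place of hydrogen gives a 1.1-fold lower number from compound 2 to compound 4 (0.04 log units; within the scatter) here. Going by these compounds alone, the change from 3,4-dimethylphenyl gives a 1.6-fold lower number from compound 1 to compound 4 (0.19 log units; within the scatter), whereas the 4-nitrophenyl counterpart gives a 2.0-fold lower number from compound 1 to compound 3 (0.31 log units; beyond the scatter) and remains the only step in this set beyond the scatter.

No measurement here explains these small differences. As far as these compounds go, whether an amine or a carboxylic acid on this aryl group would move the number outside the scatter remains open.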